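Removing the ring methyl from compound 3: expected effect

The compounds below may be only part of what the source reports. "The series", "measured", "known", "first", "only" and "open" are said of these compounds alone.

Of the compounds shown here, three have been measured in a functional assay on CCRF-CEM cells for antagonist activity at C-X-C chemokine receptor type 4 (Homo sapiens), read by calcium flux, with stated times of 25 min and 90 s; on this read-out lower numbers stand for stronger inhibition and higher numbers for weaker inhibition. Compound 1 `c1ccc2c(c1)CN[C@@H](CN(CC1CCNCC1)[C@H]1CCCc3cccnc31)C2` gives 65 nM, compound 2 `c1ccc2c(c1)CN[C@@H](CN(CC[C@@H]1CCCNC1)[C@H]1CCCc3cccnc31)C2` gives 161 nM, and compound 3 `CN1CCN(CCCN(C[C@H]2Cc3ccccc3CN2C)[C@H]2CCCc3cccnc32)CC1` gives 536 nM. Compound 3 stands highest of the three numbers; its nearest neighbour is compound 2 and its furthest is compound 1, both well beyond the scatter. Among the compounds with values here, the only single-site step recorded, a 2.5-fold higher number from compound 1 to compound 2 (0.39 log units; beyond the scatter), concerns the basic side chain and does not touch the ring nitrogen.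

Compound 4 `CN1CCN(CCCN(C[C@H]2Cc3ccccc3CN2)[C@H]2CCCc3cccnc32)CC1` differs from compound 3 by hydrogen in place of methyl on an amine nitrogen in a ring. Within the data shown here, no measured step covers this change directly. Compounds 1 and 2 both carry hydrogen on that nitrogen and give lower numbers than compound 3, but they differ elsewhere as well, so they only hint at the direction. On that basis compound 4 is expected to give a modestly lower number, a 2.1-fold lower number from compound 3 to compound 4 (0.33 log units; beyond the scatter), in this assay. The estimate for compound 4 is 250 nM, expected to fall between 100 nM and 700 nM.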

Compound 4, half-maximal inhibitory concentration: 125 nM
Estimate against measurement, compound 4: 2.0-fold (0.30 log units) above; low and high end bracket the measured number.
By their numbers in this assay, from the lowest: compounds 1, 4 and 2 (each within the scatter of the next, the first and the last beyond it); then compound 3.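

In this assay, within the data shown here, hydrogen in place of methyl on the amine nitrogen in the ring gives a 4.3-fold lower number from compound 3 to compound 4 (0.63 log units; beyond the scatter) and so provides the first direct reading of this change, which is modest but beyond the scatter. With hydrogen on that nitrogen, the side chain makes no clear difference: both a 1.3-fold lower number from compound 2 to compound 4 (0.11 log units; within the scatter) and a 1.9-fold higher number from compound 1 to compound 4 (0.28 log units; within the scatter) lie within the scatter, so the 2-(4-methylpiperazin-1-yl)ethyl chain cannot be told apart from the piperidine-bearing chains here. Nothing measured here accounts for the effect of removing the methyl.

An ethyl or acetyl group on this nitrogen could show whether the result extends beyond methyl and hydrogen. Among these compounds, the methyl change is also seen only with the piperazine side chain, so its effect alongside the piperidine-bearing chains remains open.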